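The source may report more compounds than this note shows. Statements on the series, on what has been measured and on what is new or still open speak of the compounds shown alone.

Measured in a functional assay on A549 cells (Homo sapiens) for antiproliferative activity, read by MTT assay, with a stated time of 48 h; a lower number here means a stronger inhibitor, a higher number a weaker inhibitor:
Compound 1 `CC(C)=CCC[C@]1(C)/C=C/[C@@H](OC(=O)C=C(C)C)[C@](C)(O)/C=C/C(=O)/C(CCl)=C\C1`: 150 nM
Compound 2 `CCN(CC)C/C1=C/C[C@](C)(CCC=C(C)C)/C=C/[C@@H](OC(=O)C=C(C)C)[C@](C)(O)/C=C/C1=O`: 130 nM
Compound 3 `CC(C)=CCC[C@]1(C)/C=C/[C@@H](OC(=O)C=C(C)C)[C@](C)(O)/C=C/C(=O)/C(Cn2cc(CO)nn2)=C\C1`: 3470 nM

Compound 3 stands highest of the three, and so is the weakest inhibitor here. Its steps to both others lie beyond the scatter, while compounds 1 and 2 lie within the scatter of each other, with a 1.2-fold lower number from compound 1 to compound 2 (0.06 log units; within the scatter).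

Compound 4 `CO/N=C/C1=C/C[C@](C)(CCC=C(C)C)/C=C/[C@@H](OC(=O)C=C(C)C)[C@](C)(O)/C=C/C1=O` has not yet been measured. Relative to compound 3, the (4-(hydroxymethyl)-1H-1,2,3-triazol-1-yl)methyl group is replaced on a double-bonded ring carbon: a group of 4 heavy atoms (2 carbon, 1 nitrogen, 1 oxygen; no ring) in place of a group of 8 heavy atoms (4 carbon, 3 nitrogen, 1 oxygen; one five-membered aromatic ring with 3 hetero atoms), on a double-bonded ring carbon.

For the measured compounds named here, two measured steps bear on this, as both introduce the group that now leaves. They are large: a 23-fold higher number from compound 1 to compound 3 (1.36 log units; beyond the scatter) and a 27-fold higher number from compound 2 to compound 3 (1.43 log units; beyond the scatter). Removing that group may therefore take back much of the rise. However, the entering group occurs in no measured compound, and neither chloro nor diethylamino resembles it closely, so full recovery cannot be assumed.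

In this assay, a sizeable move to a lower number is expected, namely a 7.7-fold lower number from compound 3 to compound 4 (0.89 log units; beyond the scatter). The estimate for compound 4 is 450 nM, with an expected range of 120 nM to 1800 nM.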

Compound 4, half-maximal inhibitory concentration: 3470 nM
The estimate for compound 4 lay 7.7-fold (0.89 log units) below the measured number; measured number above the stated range.
By their numbers in this assay, from the lowest: compounds 2 and 1 (each within the scatter of the next); then compounds 3 and 4 (each within the scatter of the next).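

In this assay, a group of no ring taking the place of the (4-(hydroxymethyl)-1H-1,2,3-triazol-1-yl)methyl group leaves the number unchanged, with no change at the digits printed from compound 3 to compound 4 (within the scatter), so the five-membered aromatic ring is not required for a high number at this double-bonded ring carbon. The entering group also parts compound 4 from the two low compounds, with a 27-fold higher number from compound 2 to compound 4 (1.43 log units; beyond the scatter) and a 23-fold higher number from compound 1 to compound 4 (1.36 log units; beyond the scatter), which shows that a small group without a ring does not by itself keep the number low, since the two-atom chloromethyl group of compound 1 and the diethylamino-bearing group of compound 2 do so while this four-atom group does not. Nothing measured here accounts for this division of the four compounds into two levels.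

As far as these compounds go, whether a cyclic amine such as morpholine or a primary amine on the same carbon would join compounds 1 and 2 or compounds 3 and 4 remains open. Also open, from the compounds shown here alone, is how a plain hydroxymethyl, or a triazole without its hydroxymethyl, would behave at this place.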